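The source may report more compounds than this note shows. Statements on the series, on what has been measured and on what is new or still open speak of the compounds shown alone.

In a functional assay on cells (Erythrocyte, Rattus norvegicus) for inhibition, read by hemolysis, with a stated time of 1 h (a higher number here means a weaker inhibitor, a lower number a stronger inhibitor), compound 3 (`COc1cc(OC)c(OC)cc1/C=C/C(=O)c1ccc(C)cc1`) gives 2.24 ug/mL. This lies within the scatter of compound 1 (`COc1ccc(C(=O)/C=C/c2cc(OC)c(OC)cc2OC)cc1`) at 2.18 ug/mL and of compound 2 (`COc1cc(OC)c(OC)cc1/C=C/C(=O)c1ccc(-c2c[nH]cn2)cc1`) at 2.48 ug/mL. Compound 4 (`COc1cc(OC)c(OC)cc1/C=C/C(=O)c1ccc([N+](=O)[O-])cc1`) has nitro in place of methyl on an aromatic carbon, para to a large group: nitro in place of methyl on an aromatic carbon. Three measured steps exchange the group on this carbon: a 1.1-fold higher number from compound 1 to compound 2 (0.06 log units; within the scatter), a 1.0-fold higher number from compound 1 to compound 3 (0.01 log units; within the scatter) and a 1.1-fold lower number from compound 2 to compound 3 (0.04 log units; within the scatter). Within the data shown here, all three stay within the scatter, although no measured compound carries nitro. The step expected in this assay is therefore a 1.1-fold higher number from compound 3 to compound 4 (0.03 log units; within the scatter), with no change beyond the scatter in either direction. For compound 4 the estimated value is 2.4 ug/mL, with an expected range of 1.3 ug/mL to 4.4 ug/mL.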

Compound 4, half-maximal inhibitory concentration: 2.34 ug/mL
For compound 4 the middle estimate is 1.0-fold (0.01 log units) above the measured one; low and high end bracket the measured number.
By their numbers in this assay, from the lowest: compounds 1, 3, 4 and 2 (each within the scatter of the next).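

In this assay, nitro on this aromatic carbon, para to a large group, stays within the scatter of each group compared with it: methyl (a 1.0-fold higher number from compound 3 to compound 4 (0.02 log units; within the scatter)), methoxy (a 1.1-fold higher number from compound 1 to compound 4 (0.03 log units; within the scatter)) and 1H-imidazol-4-yl (a 1.1-fold lower number from compound 2 to compound 4 (0.03 log units; within the scatter)). All four groups at this position thus give numbers within the scatter of one another, so nitro adds a further group to that flat series. Nothing available here accounts for this flatness. From the compounds shown here alone, whether an amine or a carboxylic acid on this carbon would also stay within the scatter remains open. So does whether a change elsewhere on the shared core would move the number at all.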